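The compounds below may be only part of what the source reports. "The series", "measured", "known", "first", "only" and "open" are said of these compounds alone.

Compound 2 `Cc1ccc(CN2C(=O)S/C(=C\c3cccc(N)c3)C2=O)cc1` gives 158000 nM in a functional assay on FM3A cells (Mus musculus) for cytotoxicity, read by cell counting, with a stated time of 2 days (on this read-out higher numbers stand for weaker inhibition and lower numbers for stronger inhibition), the higher of the two numbers shown in the series. Compound 1 `C=C(Br)C(=O)Nc1cccc(/C=C2\SC(=O)N(Cc3ccc(C)cc3)C2=O)c1` gives 1000 nM in this assay. Compound 3 `Cc1ccc(CN2C(=O)S/C(=C\c3ccc(N)cc3)C2=O)cc1` reaches only a limit of this assay, > 250000 nM. The step of a 160-fold higher number from compound 1 to compound 2 (2.20 log units; beyond the scatter) is large; the step of an at least 1.5-fold higher number from compound 2 to compound 3 (0.19 log units; that floor lies within the scatter) is small, and its second value is the limit (the limit of > 250000 nM in this assay, at which 1 of the 3 values shown sits). Compound 4 `Nc1cccc(/C=C2\SC(=O)N(Cc3ccc(Cl)cc3)C2=O)c1` differs from compound 2 by chloro in place of methyl on an aromatic carbon. Neither measured step touches this position, so neither bears directly on it, and no step beyond the scatter is expected from compound 2 to compound 4. The expected value for compound 4 in this assay is 150000 nM, with a range of 50000 nM to 400000 nM. This estimate means a step of a 1.1-fold lower number from compound 2 to compound 4 (0.02 log units; within the scatter).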

Compound 4, half-maximal inhibitory concentration: 246000 nM
Estimate against measurement, compound 4: 1.6-fold (0.21 log units) below; measured number inside the range.
By their numbers in this assay, from the lowest: compound 1; then compounds 2 and 4 (each within the scatter of the next). At a limit, above all of these: compound 3.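

For the compounds shown here, replacing the 4-methylphenyl group with 4-chlorophenyl is the first change at this position, and in this assay it gives a 1.6-fold higher number from compound 2 to compound 4 (0.19 log units; within the scatter), so chloro and methyl cannot be told apart here. Both compounds keep the free amino group, and their numbers lie close to the top of what this read-out can show: the limit of > 250000 nM in this assay, at which 1 of the 4 values shown sits.

Still open, on these data alone, is whether this position matters once the (1-bromoethenyl)carbonyl group of compound 1 is present. Also open, as far as these compounds go, is whether an amine or a carboxylic acid in place of methyl would move the number beyond the scatter.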